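This account rests on a few compounds, and the source may have more. Where it says the series, first, only, none or still open, it means among the compounds named here.

For the measured compounds named here, compound 2, `O=C(CCN1C(=O)CSc2ccccc21)N1CCN(c2ccc(F)cc2)CC1`, is the one compound in this set whose result in a functional assay on MDA-MB-231 cells (Homo sapiens) for inhibition, read by sulforhodamine B assay, with a stated time of 48 h (a higher number here means a weaker inhibitor of growth, a lower number a stronger inhibitor of growth), is a plain number, and there compound 2 gives 2200 nM. Going by the values given here, compound 1, `CC(C)(C)OC(=O)N1CCN(C(=O)CCN2C(=O)CSc3ccccc32)CC1`, gives in this assay only a limit, > 100000 nM; the one other value shown is that limit (the limit of > 100000 nM in this assay, at which 1 of the 2 values shown sits). Among the compounds with values here, the single measured step, an at least 45-fold lower number from compound 1 to compound 2 (1.65 log units; beyond the scatter), ran from that limit to the number of compound 2.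

Compound 3, `COc1ccccc1N1CCN(C(=O)CCN2C(=O)CSc3ccccc32)CC1`, differs from compound 2 in one place: 2-methoxyphenyl in place of 4-fluorophenyl on an amine nitrogen in a ring. The measured step concerned a carbamate giving way to an aryl group on that ring nitrogen, whereas the step to compound 3 exchanges one aryl group for another, so the measured step does not speak directly to it. With nothing to point either way, the change is expected to leave the number near that of compound 2, within the scatter or close to it, and this expectation is expressed as a 1.4-fold higher number from compound 2 to compound 3 (0.13 log units; within the scatter). Compound 3 is therefore estimated to give 3000 nM in this assay, with a plausible range from 800 nM to 12000 nM.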

Compound 3, concentration for 50% growth inhibition: 6600 nM
Estimate against measurement, compound 3: 2.2-fold (0.34 log units) below; low and high end bracket the measured number.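

With 2-methoxyphenyl in place of 4-fluorophenyl, this assay shows a 3.0-fold higher number from compound 2 to compound 3 (0.48 log units; beyond the scatter), so the choice of aryl group on this amine nitrogen does register, although the step is modest. A second aryl group also gives an at least 15-fold lower number from compound 1 to compound 3 (1.18 log units; beyond the scatter), which means that the large drop seen on leaving tert-butoxycarbonyl is not peculiar to 4-fluorophenyl, and compound 2 and compound 3 both hold it. Compound 1 remains a limit and not a number, so neither step from it has a fixed size: the limit of > 100000 nM in this assay, at which 1 of the 3 values shown sits.

Since 4-fluorophenyl and 2-methoxyphenyl differ both in the substituent and in where it stands, the compounds shown do not tell which of the two lies behind the step between compound 2 and compound 3, a question that plain phenyl, 4-methoxyphenyl or 2-fluorophenyl would separate. Also open, going by these compounds, is how far the number depends on having an aryl group directly on that nitrogen at all, as against benzyl or cyclohexyl there, and whether a longer chain between the shared core and the amide carbonyl would keep it.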